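Swapping one small azole for another on a biaryl

This account rests on a few compounds, and the source may have more. Where it says the series, first, only, none or still open, it means among the compounds named here.

Three close relatives share one core and differ only in a single group on an aromatic carbon. Compound 1 `C[C@@H](Nc1nccc(Cl)c1NC(=O)CC#N)c1ccc(-c2cccc(F)c2C(F)(F)F)cc1` carries a trifluoromethyl group there, and in an in vivo ADME assay on the whole organism (strain Sprague-Dawley) for pharmacokinetics, with Rattus norvegicus as the target, at a dose of 2 mg/kg by the intravenous route (on this read-out higher numbers stand for fast clearance and lower numbers for slow clearance), compound 1 gives 36 mL/min/kg. Compound 2 `Cc1noc(-c2c(F)cccc2-c2ccc([C@@H](C)Nc3nccc(Cl)c3NC(=O)CC#N)cc2)n1` gives 9.5 mL/min/kg in this assay, and compound 3 `C[C@@H](Nc1nccc(Cl)c1NC(=O)CC#N)c1ccc(-c2cccc(F)c2-c2nnn(C)n2)cc1` gives 9 mL/min/kg in this assay. Putting a 3-methyl-1,2,4-oxadiazol-5-yl in place of the trifluoromethyl brings a 3.8-fold lower number from compound 1 to compound 2 (0.58 log units; beyond the scatter), and putting a 2-methyl-2H-tetrazol-5-yl there brings a 4.0-fold lower number from compound 1 to compound 3 (0.60 log units; beyond the scatter). Between the two heteroaryl rings themselves the difference is only a 1.1-fold lower number from compound 2 to compound 3 (0.02 log units; within the scatter). Compound 3 therefore sits at the low end of the three numbers: its value cannot be told apart from that of compound 2, while compound 1 lies clearly higher.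

Compound 4 `Cc1nc(-c2c(F)cccc2-c2ccc([C@@H](C)Nc3nccc(Cl)c3NC(=O)CC#N)cc2)no1` differs from compound 3 by 5-methyl-1,2,4-oxadiazol-3-yl in place of 2-methyl-2H-tetrazol-5-yl on an aromatic carbon. For the measured compounds named here, the one measured exchange of one five-membered heteroaryl for another stayed within the scatter, and both heteroaryl compounds sit far from the trifluoromethyl compound. The expected step in this assay is therefore a 1.1-fold higher number from compound 3 to compound 4 (0.05 log units; within the scatter), meaning nothing beyond the scatter. Compound 4 is estimated at 10 mL/min/kg in this assay, with a range from 5 mL/min/kg to 20 mL/min/kg.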

Compound 4, clearance: 4.9 mL/min/kg
Estimate against measurement, compound 4: 2.0-fold (0.31 log units) above; the whole stated range lies above it.
By their numbers in this assay, from the lowest: compounds 4, 3 and 2 (each within the scatter of the next); then compound 1.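

In this assay, the 5-methyl-1,2,4-oxadiazol-3-yl group on this aromatic carbon, ortho to a fluoro group, gives a 1.8-fold lower number from compound 3 to compound 4 (0.26 log units; within the scatter) and a 1.9-fold lower number from compound 2 to compound 4 (0.29 log units; within the scatter). Both steps are within the scatter, so three five-membered heteroaryl rings now cannot be told apart at this place, even though compound 2 and compound 4 carry oxadiazole rings joined to the core through different ring atoms and compound 3 carries a tetrazole. The step away from trifluoromethyl, a 7.3-fold lower number from compound 1 to compound 4 (0.87 log units; beyond the scatter), is beyond the scatter, which extends the separation from compound 1 to a third heteroaryl group, although no evidence here gives a reason for that separation.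

The compounds shown leave open whether the low numbers need a five-membered aromatic ring at all, since a six-membered ring such as pyridine or an open-chain group such as a primary amide or a carboxylic acid could fall on either side of the separation. They also leave open what the methyl group on each ring contributes, which a comparison with the same rings carrying only hydrogen in its place would address.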